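Series notes: cell-growth limits and a demethylation step

This account rests on a few compounds, and the source may have more. Where it says the series, first, only, none or still open, it means among the compounds named here.

Measured so far:
Compound 1 `O=C(Nc1cccc(-n2cc(-c3ccncc3)c(-c3ccc(Cl)c(O)c3)n2)c1)Nc1cccc(C(F)(F)F)c1`: > 32500 nM, a limit
Compound 2 `COc1cc(-c2nn(-c3cccc(NC(=O)c4cccc(C(F)(F)F)c4)c3)cc2-c2ccncc2)ccc1Cl`: > 50000 nM, a limit
Compound 3 `COc1cc(-c2nn(-c3cccc(NC(=O)Nc4ccc(Cl)c(Cl)c4)c3)cc2-c2ccncc2)ccc1Cl`: > 50000 nM, a limit

In a functional assay on OVCAR-3 cells (Homo sapiens) for inhibition, read by sulforhodamine B assay, with a stated time of 48 h (a higher number here means that more compound is tolerated, a lower number that less compound is tolerated), compound 3 gives only a limit, > 50000 nM, and stands at the limit of > 50000 nM in this assay, at which 2 of the 3 values shown sit. Compound 1 likewise gives only a limit, (the limit of > 32500 nM in this assay, at which 1 of the 3 values shown sits). For the measured compounds named here, the single measured step, a step that the two limits leave unreadable from compound 2 to compound 3, is unreadable, both ends being limits. Compound 4 `O=C(Nc1cccc(-n2cc(-c3ccncc3)c(-c3ccc(Cl)c(O)c3)n2)c1)Nc1ccc(Cl)c(Cl)c1` differs from compound 3 by hydrogen in place of methyl on an oxygen on an aromatic ring. Going by the values given here, no measured step covers this change; compound 1, which carries the same hydroxy group, also reaches only a limit. Compound 4 is therefore expected to give about 50000 nM (range 20000 nM to 100000 nM), most probably reported again as a limit. The expected step of a number no higher from compound 3 to compound 4 (the limit leaves the size open) is thus estimated as none readable beyond the scatter.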

Compound 4, concentration lethal to 50% of the cells: > 32500 nM
Compound 4: no number, only a limit; the forecaster's own chance of this, stated with the estimate: 85%; the middle value is on the limit's open side.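

Compound 4 gives only a limit, so its steps from compound 3 and from compound 1 cannot be read. With only limits shown, whether methoxy to hydroxy changes the cell-killing concentration at all stays open.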